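Cyclopropylmethyl for Pentan-3-yl on a Shared Dihydropyrimidinone Ester

The compounds below may be only part of what the source reports. "The series", "measured", "known", "first", "only" and "open" are said of these compounds alone.

Measured compounds:
Compound 1, `CC1=C(C(=O)OCC2CC2)C(c2ccco2)NC(=O)N1`, gives 29% in an assay on membranes from CHO cells for displacement of a labelled ligand from adenosine receptor A1 (Homo sapiens), read by scintillation counting, with a stated time of 60 min, tested at 1 uM; a higher number here means more inhibition at the concentration tested (going by the name of the read-out), a lower number less inhibition.
Compound 2, `CCC(CC)OC(=O)C1=C(C)NC(=O)NC1c1ccoc1`, gives 17% in this assay.

Of the two measured compounds, compound 2 stands lowest in this assay; its nearest neighbour is compound 1, whose value is higher by a gap that lies beyond the usual scatter of this assay. For the measured compounds named here, no step between two measured compounds differing in a single place has been recorded, so nothing about the size of a single change is known directly.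

Compound 3, `CC1=C(C(=O)OCC2CC2)C(c2ccoc2)NC(=O)N1`, has not been measured in this assay. It differs from compound 2 in one place: cyclopropylmethyl in place of pentan-3-yl on an oxygen next to a carbonyl group. Compound 1 also carries cyclopropylmethyl on the ester oxygen, though its furan is joined at a different ring position, so it cannot serve as a direct step.

For compound 3 a small rise is expected, of about a number 7 percentage points higher from compound 2 to compound 3 (within the scatter), a shift that may still fall within the scatter. Compound 3 is accordingly estimated at 24%, with a range from 8% to 40%.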

Compound 3, a percentage reported as inhibition, at one concentration (the size of the read-out at that concentration, not a potency): 29%
Estimate against measurement, compound 3: 5 percentage points below; the range from low to high includes it.
By their numbers in this assay, from the lowest: compound 2; then compounds 1 and 3 (each within the scatter of the next).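

In this assay the ester oxygen now has a direct single-place reading: cyclopropylmethyl in place of pentan-3-yl gives a modest step (a number 12 percentage points higher from compound 2 to compound 3 (beyond the scatter)), which the earlier pair could not show, as compound 1 and compound 2 differ in more than one place. The second step, furan-3-yl in place of furan-2-yl on a saturated ring carbon (no change at the digits printed from compound 1 to compound 3 (within the scatter)), shows that with cyclopropylmethyl on the ester oxygen the two furan attachments cannot be told apart in this read-out. Nothing measured here accounts for either step.

Going by these compounds, it remains open whether the step from pentan-3-yl to cyclopropylmethyl would keep its size with furan-2-yl on the shared core, as it has been read only with furan-3-yl. Also open, on these data alone, is how other groups on the ester oxygen would read, such as a plain ethyl, a benzyl group, a longer chain, or a chain ending in an amine or a carboxylic acid.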